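Swapping an octyl chain for a difluorophenyl ring

The compounds below may be only part of what the source reports. "The series", "measured", "known", "first", "only" and "open" are said of these compounds alone.

Measured compounds:
Compound 1 `CCCCCC(=O)c1ccc(OCCCN2CCN(C(=O)OCC(C)C)CC2)cc1` gives 3720 nM in an assay on isolated protein for binding affinity to histamine H2 receptor (Homo sapiens); on this read-out higher numbers stand for weaker inhibition and lower numbers for stronger inhibition.
Compound 2 `CCCCCC(=O)c1ccc(OCCCN2CCN(C(=O)C(C)(C)O)CC2)cc1` gives 24500 nM in this assay.
Compound 3 `CCCCCCCCC(=O)c1ccc(OCCCN2CCN(C(=O)OCC)CC2)cc1` gives 2690 nM in this assay.

Among these three, compound 3 has the lowest number. Its gap to compound 1 lies within the scatter, so the two cannot be told apart; its gap to compound 2 lies beyond the scatter. Going by the values given here, the only step between two measured compounds is a 6.6-fold higher number from compound 1 to compound 2 (0.82 log units; beyond the scatter), and that change sits on the carbamate end of the shared core, far from the ketone.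

Compound 4 `CCOC(=O)N1CCN(CCCOc2ccc(C(=O)c3cccc(F)c3F)cc2)CC1` differs from compound 3 in a single place: 2,3-difluorophenyl in place of octyl on a carbonyl carbon. Among the compounds with values here, no measured step touches this part of the molecule, so there is nothing in the data to say whether a flat aromatic ring carrying two fluorines will be tolerated as well as a long flexible chain. Within the data shown here, the change keeps the count of heavy atoms, donors, acceptors and charge unchanged, which is the only guide available.

Compound 4 is therefore expected to land close to compound 3, with the step of a 1.5-fold higher number from compound 3 to compound 4 (0.17 log units; within the scatter) carrying wide uncertainty in both directions. The estimate for compound 4 in this assay is 4000 nM, within a range from 800 nM to 20000 nM.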

Compound 4, inhibition constant: 17400 nM
Compound 4: the middle estimate sits 4.4-fold (0.64 log units) below what was measured; the range from low to high includes it.
By their numbers in this assay, from the lowest: compounds 3 and 1 (each within the scatter of the next); then compounds 4 and 2 (each within the scatter of the next).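

In this assay, the carbonyl carbon whose other neighbour is an aromatic carbon proves sensitive to what it carries: replacing octyl with 2,3-difluorophenyl gives a 6.5-fold higher number from compound 3 to compound 4 (0.81 log units; beyond the scatter) and so weaker inhibition. The two groups match in heavy atoms, hydrogen-bond donors, hydrogen-bond acceptors and net charge, so this step shows that those counts alone do not settle the outcome here, something the earlier step on the carbamate end of the shared core could not show. Nothing available explains the change, and a single step cannot tell whether the result follows from losing the chain, gaining the ring or adding the two fluorines.

On these data alone, a plain phenyl ring without fluorine and a saturated cyclohexyl ring at the same place would help separate those possibilities, and where either would fall relative to compound 3 and compound 4 remains open. As far as these compounds go, it is also open whether the same swap has a similar effect when the carbamate end carries a different group, such as the isobutoxy group of compound 1.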